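This account rests on a few compounds, and the source may have more. Where it says the series, first, only, none or still open, it means among the compounds named here.

In a functional assay on MCF7 cells (Homo sapiens) for inhibition, read by trypan blue exclusion, with a stated time of 3 days (a lower number here means a stronger inhibitor, a higher number a weaker inhibitor), compound 1 (`COc1cc(C(=O)c2cn(-c3ccccc3F)cc2-c2ccccc2)cc(OC)c1OC`) gives 85 nM and compound 2 (`COc1cc(C(=O)c2cn(-c3ccc(C)cc3)cc2-c2ccccc2)cc(OC)c1OC`) gives 30 nM, the lower of the two numbers. Compound 3 (`COc1cc(C(=O)c2cn(-c3ccc(F)cc3)cc2-c2ccccc2)cc(OC)c1OC`) differs from compound 2 by fluoro in place of methyl on an aromatic carbon, para to a large group. For the measured compounds named here, the one measured step, a 2.8-fold lower number from compound 1 to compound 2 (0.45 log units; beyond the scatter), also changes the group on the aromatic nitrogen, but it is a different exchange and offers only loose guidance. The expected step is a 1.7-fold higher number from compound 2 to compound 3 (0.22 log units; within the scatter), a somewhat higher number and smaller than that measured step. For compound 3 the estimated value in this assay is 50 nM, with an expected range of 20 nM to 130 nM.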

Compound 3, half-maximal inhibitory concentration: 15 nM
Estimate against measurement, compound 3: 3.3-fold (0.52 log units) above; measured number below the stated range.
By their numbers in this assay, from the lowest: compounds 3 and 2 (each within the scatter of the next); then compound 1.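

In this assay, the exchange of methyl for fluoro on this aromatic carbon gives a 2.0-fold lower number from compound 2 to compound 3 (0.30 log units; within the scatter), so 4-methylphenyl and 4-fluorophenyl cannot be told apart here. With fluoro on both sides, 4-fluorophenyl in place of 2-fluorophenyl gives a 5.7-fold lower number from compound 1 to compound 3 (0.75 log units; beyond the scatter), which shows that the place of the fluoro on the ring matters beyond the scatter. Nothing on hand accounts for either step.

Still open, on these data alone, is how chloro, methoxy or a dimethylamino group on that aromatic carbon would read in this assay. Also open, as far as these compounds go, is whether the gap between the two fluoro placements holds for 2-methylphenyl against 4-methylphenyl.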